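The source may report more compounds than this note shows. Statements on the series, on what has been measured and on what is new or still open speak of the compounds shown alone.

Measured so far in a toxicity assay on THP-1 cells (Homo sapiens) for inhibition; on this read-out higher numbers stand for lower toxicity in this test and lower numbers for higher toxicity in this test:
compound 1 `Cn1c(-c2cccc([N+](=O)[O-])c2)cnc1NC(=O)c1ccc(F)cc1`: > 50000 nM
compound 2 `COc1ccc(-c2noc(NC(=O)c3ccc(F)cc3)c2C)cc1`: > 100000 nM
compound 3 `COc1ccc(-c2cnc(NC(=O)C3CCCCC3)n2C)cc1`: > 100000 nM

Each of these readings is a limit of the test, not a number. Compound 1 sits at the limit of > 50000 nM in this assay, at which 1 of the 3 values shown sits. Compound 2 and compound 3 sit at the limit of > 100000 nM in this assay, at which 2 of the 3 values shown sit. So compound 1 stands with the other two: no cytotoxic effect was found within the tested range, and no step between measured compounds can be drawn from these values.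

Compound 4 `Cn1c(-c2cccc(Br)c2)cnc1NC(=O)c1ccc(F)cc1` differs from compound 1 in one place: bromo in place of nitro on an aromatic carbon. Going by the values given here, no measured step shows what this change does in this assay. Because compound 1 gives only a limit, > 50000 nM, compound 4 is expected to show no measurable toxicity either. The expected step that the limit leaves unreadable from compound 1 to compound 4 is none beyond the scatter. Compound 4 is estimated at 80000 nM, between 30000 nM and 200000 nM, most likely reported again only as a limit.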

Compound 4, half-maximal cytotoxic concentration: > 50000 nM
Compound 4 was reported as a limit (the forecaster's own chance of this, stated with the estimate: 80%); the middle value is on the limit's open side.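

Compound 1 and compound 4 each give only a limit of the test, and the swap of nitro for bromo yields no readable step. The compounds shown leave open what structural change, if any, would produce a measurable value in this assay.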